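Swapping a Benzyl Ester Chain for Isopropyl in Tail Flick

This account rests on a few compounds, and the source may have more. Where it says the series, first, only, none or still open, it means among the compounds named here.

The set comprises three measured compounds and one awaiting measurement. Compound 1 `O=C(CN(c1nc(Cl)nc2[nH]cnc12)C1CC1)NCC(=O)OCc1ccccc1`, compound 2 `O=C(CN(c1ncnc2c1ncn2C1CCCCO1)C1CC1)N[C@@H](CCC(=O)OCc1ccccc1)C(=O)OCc1ccccc1` and compound 3 `O=C(CN(c1nc(Cl)nc2[nH]cnc12)C1CC1)N[C@@H](CC(=O)OCc1ccccc1)C(=O)OCc1ccccc1` share a common core and were tested in a functional assay on the whole organism (Tail, strain ICR) with Mus musculus as the target, in the tail flick test, with a stated time of 150 min, at a dose of 25 umol/kg by the oral route; a higher number here means a stronger effect of the compound at the dose given, a lower number a weaker effect. In this assay compound 1 gives 18%, compound 2 gives 14.1% and compound 3 gives 6.68%. Compound 2 thus stands second of the three numbers, within the scatter of both compound 1 and compound 3. Going by the values given here, the one single-point step among them is a number 11.3 percentage points lower from compound 1 to compound 3 (beyond the scatter), a modest loss that lies beyond the scatter.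

Compound 4 `CC(C)[C@H](NC(=O)CN(c1ncnc2c1ncn2C1CCCCO1)C1CC1)C(=O)OCc1ccccc1` differs from compound 2 in one place: isopropyl in place of 2-(benzyloxycarbonyl)ethyl on a saturated chain carbon bound to an amide-type nitrogen and a carbonyl carbon. The step from compound 1 to compound 3 bears on this, since it likewise concerns what hangs on the saturated chain carbon bound to an amide-type nitrogen and a carbonyl carbon; there, adding (benzyloxycarbonyl)methyl cost activity. Removing the 2-(benzyloxycarbonyl)ethyl chain in favour of isopropyl might therefore be expected to move the number upward modestly, though compound 4 keeps a substituent rather than hydrogen and the direction is uncertain. Compound 4 is expected to give 20%, within 8% to 34%. The step of a number 5.9 percentage points higher from compound 2 to compound 4 (within the scatter) is therefore expected to be small, close to the scatter.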

Compound 4, a percentage reported as activity, at one dose (the size of the read-out at that dose, not a potency): 21.1%
Estimate against measurement, compound 4: 1.1 percentage points below; the measured number falls inside the stated range.
By their numbers in this assay, from the lowest: compounds 3, 2, 1 and 4 (each within the scatter of the next, the first and the last beyond it).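

In this assay, isopropyl in place of 2-(benzyloxycarbonyl)ethyl gives a number 7 percentage points higher from compound 2 to compound 4 (within the scatter), so in this pair the chain and its six-membered aromatic ring can be exchanged for a small branched group with no difference that can be told from the scatter. The earlier step at this saturated chain carbon, a number 11.3 percentage points lower from compound 1 to compound 3 (beyond the scatter), lay beyond the scatter, but it started from hydrogen on the core of compound 1, whereas the new step exchanges one substituent for another on the core of compound 2. Nothing measured here offers an explanation for either result.

The compounds shown leave open how a carboxylic acid, an aminoethyl chain or a longer unbranched alkyl chain on this carbon would read, and whether isopropyl would give a similar number on the core of compound 1. Since each number comes from one dose at one stated time, they also leave open how these compounds would compare in potency or at other times.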